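A few compounds are considered here, and "the series" means these few. Any claim that something is new, unique, unknown or untested is made for them only; others in the source may bear on it.

Compound 2 `CCCCOc1ccc(C(CC)NC(=O)Oc2ccc(F)cc2F)cc1` shares its core with compound 1 `CCCCOc1ccc(C(CC)NC(=O)Oc2cccc(N(C)C)c2)cc1`; the two differ only in the ring on the oxygen next to a carbonyl group. Among the measured compounds shown here, in an assay on H4 cells for inhibition of Fatty-acid amide hydrolase 1 (Homo sapiens) (a higher number here means a weaker inhibitor, a lower number a stronger inhibitor), compound 1 gives 54 nM, and compound 2 gives 21 nM, the lower of the two numbers so far. For the measured compounds named here, the single measured step, a 2.6-fold lower number from compound 1 to compound 2 (0.41 log units; beyond the scatter), swaps the entire ring, so it speaks only loosely to a smaller change on that ring. Compound 3 `CCCCOc1ccc(C(CC)NC(=O)Oc2ccc(F)cc2)cc1` differs from compound 2 by hydrogen in place of fluoro on an aromatic carbon. Going by the values given here, no measured pair removes a single fluoro, so the expectation rests on the modest size of a 2.6-fold lower number from compound 1 to compound 2 (0.41 log units; beyond the scatter) and on the fact that only part of the ring now changes. Compound 3 is therefore expected to move little, by a 1.5-fold higher number from compound 2 to compound 3 (0.18 log units; within the scatter). The value of compound 3 is estimated at 32 nM, within a range from 12 nM to 80 nM.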

Compound 3, half-maximal inhibitory concentration: 12 nM
Estimate against measurement, compound 3: 2.7-fold (0.43 log units) above; the range from low to high includes it.
By their numbers in this assay, from the lowest: compounds 3 and 2 (each within the scatter of the next); then compound 1.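

In this assay the step of a 1.8-fold lower number from compound 2 to compound 3 (0.24 log units; within the scatter) shows that the fluoro group ortho to a large group can give way to hydrogen without a change that can be told from the scatter, so compound 2 and compound 3 cannot be ranked against each other. With that fluoro group gone, the 4-fluorophenyl ring still stands apart from the 3-(dimethylamino)phenyl ring, with a 4.5-fold lower number from compound 1 to compound 3 (0.65 log units; beyond the scatter) as the step, and that step is larger than the one seen with the 2,4-difluorophenyl ring. No measurement offered here explains why either ring behaves as it does.

The compounds shown leave open whether the other fluoro group matters, which a plain phenyl ring would test. They also leave open how a larger group, such as chloro or methoxy, would fare on the aromatic carbon that now carries hydrogen.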